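This account rests on a few compounds, and the source may have more. Where it says the series, first, only, none or still open, it means among the compounds named here.

Compound 1 `O=C1O[C@@H](CO)CN1c1ccc(-n2cc(-c3ccccn3)cn2)c(F)c1`, compound 2 `O=C1CCC(=O)N1C[C@H]1CN(c2ccc(-n3cc(-c4ccccn4)cn3)c(F)c2)C(=O)O1` and compound 3 `COC[C@H]1CN(c2ccc(-n3cc(-c4ccccn4)cn3)c(F)c2)C(=O)O1` differ only in the group on a saturated chain carbon bound to a saturated ring carbon. In an ADME assay on L02 cells (Homo sapiens) for cytotoxicity, read by MTT assay, with a stated time of 48 h (on this read-out higher numbers stand for weaker inhibition and lower numbers for stronger inhibition), compound 1 gives 59 ug/mL. Compound 2 gives > 400 ug/mL, which is a limit. Compound 3 gives > 400 ug/mL, also a limit, and so stands at the limit of > 400 ug/mL in this assay, at which 2 of the 3 values shown sit.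

Compound 4 `CS(=O)(=O)NC[C@H]1CN(c2ccc(-n3cc(-c4ccccn4)cn3)c(F)c2)C(=O)O1` carries methanesulfonamido in place of methoxy on a saturated chain carbon bound to a saturated ring carbon. Among the compounds with values here, two measured steps bear on this: an at least 6.7-fold higher number from compound 1 to compound 2 (0.83 log units; beyond the scatter) and an at least 6.7-fold higher number from compound 1 to compound 3 (0.83 log units; beyond the scatter). Beyond these, there is a step that the two limits leave unreadable from compound 2 to compound 3. Neither replacement of hydroxy gave a number, so this assay is expected to stay high, with a modest move to lower numbers at most. The expected step is an at least 1.1-fold lower number from compound 3 to compound 4 (0.05 log units; that floor lies within the scatter). For compound 4 the estimate is 350 ug/mL, within 90 ug/mL to 700 ug/mL.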

Compound 4, half-maximal inhibitory concentration: > 400 ug/mL
Compound 4 gave a limit, no number; the forecaster's own chance of this, stated with the estimate: 55%; middle value at least 1.1-fold (0.05 log units) from the limit.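

In this assay, methanesulfonamido brings a hydrogen-bond donor that methoxy lacks, yet this third replacement of hydroxy on the saturated chain carbon also moves away from compound 1, with an at least 6.7-fold higher number from compound 1 to compound 4 (0.83 log units; beyond the scatter). The steps from compound 2 and compound 3 to compound 4 cannot be read, as both ends of each are limits. Compound 4 likewise gives only a limit: the limit of > 400 ug/mL in this assay, at which 3 of the 4 values shown sit.

On these data alone, the order among compound 2, compound 3 and compound 4 stays unknown. As far as these compounds go, whether an amine or a carboxylic acid at this place would give a number or another limit remains open.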